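Methyl for cyano on the benzamide ring of an orexin antagonist

A few compounds are considered here, and "the series" means these few. Any claim that something is new, unique, unknown or untested is made for them only; others in the source may bear on it.

Measured so far:
compound 1 `Cc1ccc(-n2nccn2)c(C(=O)N2CC3(CC3)C[C@H]2CNc2ccc(Cl)cn2)c1`, < 5
compound 2 `O=C(c1ncccc1-c1ncccn1)N1CC2(CC2)C[C@H]1CNc1ccc(C(F)(F)F)cn1`, 5
compound 3 `N#Cc1ccc(-c2ncccn2)c(C(=O)N2CC3(CC3)C[C@H]2CNc2ccc(C(F)(F)F)cn2)c1`, 8.1

Of the compounds shown here, three share a spirocyclic amide core and have been tested in a functional assay on HEK293 cells for antagonist activity at Orexin receptor type 2 (Homo sapiens), read by FLIPR and calcium flux; a higher number here means a more potent compound, by a factor of ten per unit of this negative logarithm, a lower number a less potent compound. Compound 3 `N#Cc1ccc(-c2ncccn2)c(C(=O)N2CC3(CC3)C[C@H]2CNc2ccc(C(F)(F)F)cn2)c1` gives 8.1 in this assay. For compound 1 `Cc1ccc(-n2nccn2)c(C(=O)N2CC3(CC3)C[C@H]2CNc2ccc(Cl)cn2)c1` this assay reports only a limit, < 5; that is the limit of < 5 in this assay, at which 1 of the 3 values shown sits. Compound 2 `O=C(c1ncccc1-c1ncccn1)N1CC2(CC2)C[C@H]1CNc1ccc(C(F)(F)F)cn1` gives 5 in this assay. Compound 3 therefore stands highest of the two numbers shown, and its gap to compound 2 lies beyond the scatter.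

Compound 4 `Cc1ccc(-c2ncccn2)c(C(=O)N2CC3(CC3)C[C@H]2CNc2ccc(C(F)(F)F)cn2)c1` differs from compound 3 in one place: methyl in place of cyano on an aromatic carbon, a methyl in place of cyano on an aromatic carbon. Going by the values given here, no measured pair isolates this change, so its size is unknown. Among the compounds with values here, compound 1, the one methyl-bearing analogue, sits at a limit, but it also differs elsewhere, so it gives no direct guide. A loss is expected for compound 4, estimated at 7 with a range from 5.8 to 8.2, a step of a number 1.10 log units lower from compound 3 to compound 4 (beyond the scatter).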

Compound 4, negative logarithm of the antagonist equilibrium constant: 6.6
Beside the measured number, compound 4's estimate is 0.40 log units above it; the range from low to high includes it.
By their numbers in this assay, from the lowest: compound 2; then compound 4; then compound 3.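

Compound 3 and compound 4 are the first pair shown that isolates a single change, so its size can now be read: in this assay, methyl in place of cyano on this aromatic carbon, para to a pyrimidin-2-yl group, gives a number 1.50 log units lower from compound 3 to compound 4 (beyond the scatter). This position is therefore sensitive to this exchange, although that rests on one pair alone. Nothing shown gives a cause for the step.

On these data alone, it remains open whether the step reflects the arrival of methyl or the departure of cyano, and what a fluorine atom, a methoxy group or an amine would give on the same carbon. Also open, as far as these compounds go, is whether the exchange would have a step of similar size with another group in place of the pyrimidin-2-yl group.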